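The source may report more compounds than this note shows. Statements on the series, on what has been measured and on what is new or still open speak of the compounds shown alone.

Compound 2 `O=C(/C=C/c1ccc(Br)cc1)Nc1cc2c(Nc3ccc(F)c(Cl)c3)ncnc2cc1O[C@H]1CCOC1` is measured in a functional assay on MCF7 cells (Homo sapiens) for cytotoxicity, read by MTT assay, with a stated time of 72 h (a lower number here means a stronger inhibitor, a higher number a weaker inhibitor), at 32400 nM. Compound 1 `COc1cc(/C=C/C(=O)Nc2cc3c(Nc4ccc(F)c(Cl)c4)ncnc3cc2O[C@H]2CCOC2)cc(OC)c1` gives 30300 nM in this assay. Compound 2 carries the higher of the two numbers, but the step of a 1.1-fold higher number from compound 1 to compound 2 (0.03 log units; within the scatter) is within the scatter, so the two compounds cannot be ordered.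

Compound 3 `N#Cc1ccc(/C=C/C(=O)Nc2cc3c(Nc4ccc(F)c(Cl)c4)ncnc3cc2O[C@H]2CCOC2)cc1` has not yet been measured. It differs from compound 2 by cyano in place of bromo on an aromatic carbon. Going by the values given here, the one step available at the same aromatic ring, a 1.1-fold higher number from compound 1 to compound 2 (0.03 log units; within the scatter), replaced the whole substituted ring and produced no movement beyond the scatter. Among the compounds with values here, no step that trades bromo for cyano exists in this set. The step from compound 2 to compound 3 is therefore expected to be small, with no direction favoured, as a 1.1-fold lower number from compound 2 to compound 3 (0.03 log units; within the scatter) states. For compound 3 the estimate in this assay is 30000 nM, with a range from 12000 nM to 80000 nM.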

Compound 3, half-maximal inhibitory concentration: 9830 nM
Estimate against measurement, compound 3: 3.1-fold (0.48 log units) above, and the stated range ends above it.
By their numbers in this assay, from the lowest: compound 3; then compounds 1 and 2 (each within the scatter of the next).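

In this assay, going by these compounds alone, the position on the aromatic ring para to a large group now proves responsive to the substituent: cyano in place of bromo gives a 3.3-fold lower number from compound 2 to compound 3 (0.52 log units; beyond the scatter), the first step in this set beyond the scatter. The replacement of 3,5-dimethoxyphenyl by 4-cyanophenyl gives a step of similar size, a 3.1-fold lower number from compound 1 to compound 3 (0.49 log units; beyond the scatter), whereas 3,5-dimethoxyphenyl and 4-bromophenyl could not be ordered. No measurement available here bears on why the number falls with cyano.

The compounds shown leave open whether the lower number is specific to cyano or would also appear with other groups at this position, such as an amine, a carboxylic acid or trifluoromethyl. They also leave open whether the step from bromo to cyano would hold in any other cell line.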